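Swapping 2-Hydroxyphenyl for 2,4-Dichlorophenyl

This account rests on a few compounds, and the source may have more. Where it says the series, first, only, none or still open, it means among the compounds named here.

In a functional assay (Homo sapiens) for inhibition (on this read-out higher numbers stand for weaker inhibition and lower numbers for stronger inhibition), compound 1 (`COc1ccc(C(=O)/C=C/c2ccccc2F)c(OC)c1OC`) gives 11000 nM while compound 2 (`COc1ccc(C(=O)/C=C/c2ccc(C#N)cc2)c(OC)c1OC`) gives 5400 nM and compound 3 (`COc1ccc(C(=O)/C=C/c2ccccc2O)c(OC)c1OC`) gives 9000 nM as its reading. These three share a core and differ only in the aromatic group on the double-bonded chain. Compound 3 lies inside the range set by the other two, and neither of its gaps exceeds the scatter, as the steps show (a 1.2-fold lower number from compound 1 to compound 3 (0.09 log units; within the scatter); a 1.7-fold higher number from compound 2 to compound 3 (0.22 log units; within the scatter)). Compound 4 (`COc1ccc(C(=O)/C=C/c2ccc(Cl)cc2Cl)c(OC)c1OC`) differs from compound 3 at this same place (2,4-dichlorophenyl in place of 2-hydroxyphenyl on a double-bonded chain carbon bound to a double-bonded chain carbon). In words, 2,4-dichlorophenyl stands in place of 2-hydroxyphenyl on a double-bonded chain carbon bound to a double-bonded chain carbon. Within the data shown here, no measured compound carries chlorine, so the evidence is indirect. The measured steps at this place are the best guide, and the largest of them (a 2.0-fold lower number from compound 1 to compound 2 (0.31 log units; beyond the scatter)) is modest. A step beyond the scatter therefore seems unlikely in this assay and no firm direction can be expected. The estimated step is small (a 1.3-fold lower number from compound 3 to compound 4 (0.11 log units; within the scatter)) and stays within the scatter. Compound 4 is expected to read about 7000 nM with an estimated range from 2800 nM to 17000 nM in this measurement.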

Compound 4, half-maximal inhibitory concentration: 7800 nM
Estimate against measurement, compound 4: 1.1-fold (0.05 log units) below, and the stated range covers the measured number.
By their numbers in this assay, from the lowest: compounds 2, 4, 3 and 1 (each within the scatter of the next, the first and the last beyond it).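

In this assay, this position takes a change of a new kind: 2-hydroxyphenyl, which has a hydrogen-bond donor and acceptor, gives way to 2,4-dichlorophenyl, which has neither, and the step stays small (a 1.2-fold lower number from compound 3 to compound 4 (0.06 log units; within the scatter)). Among these compounds, compound 4 also stays close to the other two compounds, with a 1.4-fold higher number from compound 2 to compound 4 (0.16 log units; within the scatter) and a 1.4-fold lower number from compound 1 to compound 4 (0.15 log units; within the scatter), so the first chlorine-bearing group in this set gives a reading that cannot be told apart from any of the three earlier ones, even though compound 1 and compound 2 are separated by a step just beyond the scatter. Nothing available here explains why these different aromatic groups give such similar readings.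

The compounds shown leave open whether any group on this chain carbon can produce a large step, for example an aminophenyl group, a benzoic acid group with its carboxylic acid, or a saturated ring such as cyclohexyl in place of the aromatic ring. They also leave open whether the shared core, rather than this position, is the better place to look for a large change in the reading.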